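The compounds below may be only part of what the source reports. "The series", "measured", "known", "first", "only" and "open" are said of these compounds alone.

Measured so far:
Compound 1, `COc1ccc(S(=O)(=O)c2cccc(N)c2C#N)cc1`, in a functional assay on MT4 cells (Homo sapiens) for cytotoxicity (a lower number here means a stronger inhibitor, a higher number a weaker inhibitor), gives > 200000 nM, which is a limit of the assay and not a number.
Compound 2, `Cc1ccc(S(=O)(=O)c2cccc(N)c2C#N)cc1`, in this assay gives > 200000 nM, likewise a limit.

Compound 2 therefore stands at the limit of this assay, and so does every value shown (the limit of > 200000 nM in this assay, at which 2 of the 2 values shown sit). Compound 3, `N#Cc1ccc(S(=O)(=O)c2cccc(N)c2C#N)cc1`, differs from compound 2 by cyano in place of methyl on an aromatic carbon. For the measured compounds named here, the one measured step, a step that the two limits leave unreadable from compound 1 to compound 2, is unreadable in size because both of its ends are limits, so it offers no guide to the direction or size of the step to compound 3. With both known values sitting at the limit, nothing here points to a step beyond the scatter. Compound 3 is thus expected to sit at about 250000 nM, within a range from 100000 nM to 600000 nM. The expected step that the limit leaves unreadable from compound 2 to compound 3 is correspondingly small, and most likely the assay will again report only a limit.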

Compound 3, half-maximal inhibitory concentration: > 200000 nM
Compound 3: a limit, no number; the forecaster's own chance of this, stated with the estimate: 80%; the middle value does not contradict the limit.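

In this assay, for the compounds shown here, compound 1, compound 2 and compound 3 all give a limit and not a number, so no step among them can be read: the limit of > 200000 nM in this assay, at which 3 of the 3 values shown sit. The compounds shown leave open whether swapping methoxy, methyl and cyano changes the result at all, and at what concentration any of the three would reach half-maximal inhibition.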